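The source may hold more compounds than are shown below. What is called first, only, known or untested is meant among the compounds shown, and "the series" means these compounds.

Measured so far in an ADME assay on HEK293 cells (Homo sapiens) for cytotoxicity, read by MTT assay, with a stated time of 48 h; on this read-out lower numbers stand for stronger inhibition and higher numbers for weaker inhibition:
compound 1, `Cc1cc(NC(=O)c2cccc(C(F)(F)F)c2)ccc1NS(C)(=O)=O`: 194000 nM
compound 2, `CCS(=O)(=O)Nc1ccc(NC(=O)c2cccc(C(F)(F)F)c2)cc1C`: 210000 nM
compound 3, `COc1cc(NC(=O)c2cccc(C(F)(F)F)c2)ccc1NS(C)(=O)=O`: > 250000 nM, which is a limit of the assay and not a number

From compound 1 to compound 2 the change is methyl in place of hydrogen on a saturated chain carbon bound to a sulfonyl sulfur, and the step is a 1.1-fold higher number from compound 1 to compound 2 (0.03 log units; within the scatter). The core of compound 3 differs from that of compound 1 by methoxy in place of methyl on an aromatic carbon, with a step of an at least 1.2-fold higher number from compound 1 to compound 3 (0.11 log units; that floor lies within the scatter). Compound 4, `CCS(=O)(=O)Nc1ccc(NC(=O)c2cccc(C(F)(F)F)c2)cc1OC`, is not yet measured; against compound 3 it carries the same change, (methyl in place of hydrogen on a saturated chain carbon bound to a sulfonyl sulfur). Compound 3 sits at the limit of > 250000 nM in this assay, at which 1 of the 3 values shown sits. Given that and a 1.1-fold higher number from compound 1 to compound 2 (0.03 log units; within the scatter), compound 4 is expected to land at or past the same limit, a step that the limit leaves unreadable from compound 3 to compound 4. Compound 4 is estimated at 300000 nM, between 200000 nM and 500000 nM, most likely reported again only as a limit.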

Compound 4, half-maximal inhibitory concentration: > 250000 nM
Compound 4: a limit, no number; the forecaster's own chance of this, stated with the estimate: 80%; the middle value lies beyond the limit too.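

In this assay, methoxy in place of methyl on an aromatic carbon gives an at least 1.1-fold higher number from compound 2 to compound 4 (0.07 log units; that floor lies within the scatter), so this core also yields only a floor. Set beside the core of compound 1, the two floors do not conflict, yet they fix no size for the change on either core: the same change on two cores in this assay, an at least 1.2-fold higher number (0.11 log units; that floor lies within the scatter) from compound 1 to compound 3 and an at least 1.1-fold higher number (0.07 log units; that floor lies within the scatter) from compound 2 to compound 4; the limit leaves it open whether they differ

The step for methyl to ethyl on the core of compound 3 cannot be read, and the values shown offer no numbers for the methoxy pair: the limit of > 250000 nM in this assay, at which 2 of the 4 values shown sit.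

On these data alone, whether methoxy in place of methyl has any real effect on this read-out stays open. So does whether a longer chain on the sulfonyl group, or an amine or carboxylic acid in place of trifluoromethyl, would give a value short of the limit.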